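A few compounds are considered here, and "the series" means these few. Any claim that something is new, unique, unknown or untested is made for them only; others in the source may bear on it.

Working notes on the series. Two measured compounds set the frame. Going by the values given here, compound 1 `COc1ccc(-c2cccc(C(=O)N(C)C)c2)cc1S(=O)(=O)Nc1ccc2ccc(NC(=O)c3ccccc3)cc2c1` is the first of them. In a functional assay on CHO cells for agonist activity at Orexin/Hypocretin receptor type 1 (Homo sapiens) (a lower number here means that less compound is needed, a higher number that more compound is needed for the effect), compound 1 reaches only a limit of the assay, > 10000 nM. Compound 2 `COc1cccc(C(=O)Nc2cccc3ccc(NS(=O)(=O)c4cc(-c5cccc(C(=O)N(C)C)c5)ccc4OC)cc23)c1` is the second. In this assay, among the compounds with values here, compound 2 gives 473 nM, which is the only actual number among the measured values. The remaining value is a limit, as recorded in the limit of > 10000 nM in this assay, at which 1 of the 2 values shown sits. Compound 3 `COc1cccc(C(=O)N(C)c2cccc3ccc(NS(=O)(=O)c4cc(-c5cccc(C(=O)N(C)C)c5)ccc4OC)cc23)c1` has not yet been measured. The change from compound 2 to compound 3 is methyl in place of hydrogen on an amide-type nitrogen. Within the data shown here, no single-point step between measured compounds exists in this set, so the size of this change has to be estimated rather than read off. The expected step is a loss of potency somewhat beyond the scatter: a 3.2-fold higher number from compound 2 to compound 3 (0.50 log units; beyond the scatter). Compound 3 is accordingly estimated at 1500 nM, with a range from 400 nM to 6000 nM.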

Compound 3, half-maximal effective concentration: 232 nM
Compound 3: middle estimate off by 6.5-fold (0.81 log units), on the high side; measured number below the stated range.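

In this assay, going by these compounds alone, methyl in place of hydrogen on an amide-type nitrogen gives a 2.0-fold lower number from compound 2 to compound 3 (0.31 log units; beyond the scatter) and is the first single-point step available. The amide hydrogen is therefore not required for agonist activity in this pair, and this position accepts a methyl with a modest shift toward less compound needed. Nothing measured here accounts for the direction of this step.

The compounds shown leave open whether a longer chain such as ethyl, or a chain ending in an amine, on this same nitrogen would keep the lower number. They also leave open whether the same methyl would have a similar effect on the core of compound 1, which reads only as a limit of > 10000 nM in this assay.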